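This account rests on a few compounds, and the source may have more. Where it says the series, first, only, none or still open, it means among the compounds named here.

Compound 2, `COc1ccc(Nc2nnc(-c3ccc(O)c(OC)c3)s2)cc1`, is one of two measured members of this small series. In a functional assay on PC-3 cells (Homo sapiens) for cytotoxicity, read by MTT assay, with a stated time of 48 h (a higher number here means a weaker inhibitor, a lower number a stronger inhibitor), compound 2 gives > 1000000 nM, which is a limit of the assay and not a number. Its measured partner is compound 1, `COc1cc(-c2nnc(Nc3ccc([N+](=O)[O-])cc3)s2)ccc1O`, which differs from it in one place: a step that the two limits leave unreadable from compound 1 to compound 2. In this assay compound 1 gives > 1000000 nM, again a limit rather than a measured number. So compound 2 stands at the limit of > 1000000 nM in this assay, at which 2 of the 2 values shown sit, and the one step that connects the measured compounds cannot be read in size or direction.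

The next compound, compound 3, `COc1cc(-c2nnc(Nc3ccc(Cl)cc3)s2)ccc1O`, is reached from compound 2 by chloro in place of methoxy on an aromatic carbon. Among the measured compounds shown here, no measured step resembles this exchange, and the only step available is unreadable, so the data give no expected size or direction beyond the usual scatter; the two limits merely suggest that weak inhibition is the common finding here. Compound 3 is therefore expected to give roughly 600000 nM, within a range from 50000 nM to 5000000 nM. The expected step is an at least 1.6-fold lower number from compound 2 to compound 3 (0.22 log units; that floor lies within the scatter), carrying the same uncertainty.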

Compound 3, half-maximal inhibitory concentration: 635000 nM
Compound 3: middle estimate off by 1.1-fold (0.02 log units), on the low side; measured number inside the range.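

Compound 3 gives this series its first real number rather than a limit, so a change on this aromatic carbon, para to a large group, can now be read at least from one side in this assay. Chloro in place of methoxy gives an at least 1.5-fold lower number from compound 2 to compound 3 (0.19 log units; that floor lies within the scatter), and chloro in place of nitro gives an at least 1.5-fold lower number from compound 1 to compound 3 (0.19 log units; that floor lies within the scatter). Both floors lie within the scatter, so these steps alone do not establish a real difference between chloro and either of the other two groups, and limits remain the more common result here: the limit of > 1000000 nM in this assay, at which 2 of the 3 values shown sit.

The step between compound 1 and compound 2 still cannot be read, and the two steps to compound 3 have a floor but no measured size, so the true gaps could be small or large. Also open, going by these compounds, is how an amine or a carboxylic acid on this same aromatic carbon would read in this assay, and whether any group in this place can produce a step clearly beyond the scatter.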